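The compounds below may be only part of what the source reports. "The series", "measured", "known", "first", "only" and "open" are said of these compounds alone.

Compound 1 `COc1cc(N2C(N)=C(C#N)C(c3cccs3)C3=C2CC(C)(C)CC3=O)cc(OC)c1OC` gives 15% in a functional assay on Ehrlich cells (Mus musculus) for cytotoxicity, tested at 50 ug/mL; on this read-out lower numbers stand for a weaker effect and higher numbers for a stronger effect at the one concentration tested.
Compound 2 `COc1cc(N2C(N)=C(C#N)C(c3ccc(O)cc3)C3=C2CC(C)(C)CC3=O)cc(OC)c1OC` gives 90%.
Compound 3 `COc1cc(N2C(N)=C(C#N)C(/C=C/c3ccccc3)C3=C2CC(C)(C)CC3=O)cc(OC)c1OC` gives 30%.

Among these three numbers compound 1 stands lowest: compound 3 comes nearest, a number 15 percentage points higher from compound 1 to compound 3 (beyond the scatter), and compound 2 lies furthest, a number 75 percentage points higher from compound 1 to compound 2 (beyond the scatter). Compound 4 `COc1cc(N2C(N)=C(C#N)C(c3ccc(C)o3)C3=C2CC(C)(C)CC3=O)cc(OC)c1OC` differs from compound 1 in one place: 5-methylfuran-2-yl in place of thiophen-2-yl on a saturated ring carbon. Both measured steps away from compound 1 replaced the thiophen-2-yl with a group that has no five-membered aromatic ring, and both raised the read-out, modestly in one case and strongly in the other. The change to 5-methylfuran-2-yl keeps a five-membered aromatic ring with one hetero atom, so a smaller step is expected, at most slightly upward. For compound 4 the expected value in this assay is 25%, within 5% to 55%, meaning an expected step of a number 10 percentage points higher from compound 1 to compound 4 (within the scatter).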

Compound 4, a percentage reported as activity, at one concentration (the size of the read-out at that concentration, not a potency): 41%
The estimate for compound 4 lay 16 percentage points below the measured number; low and high end bracket the measured number.
By their numbers in this assay, from the lowest: compound 1; then compound 3; then compound 4; then compound 2.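

Keeping a five-membered aromatic ring with 1 hetero atom does not leave this assay unchanged: there is a number 26 percentage points higher from compound 1 to compound 4 (beyond the scatter) in this read-out, so the outcome at this saturated ring carbon depends on more than that ring count. The 5-methylfuran-2-yl also gives a number 11 percentage points higher from compound 3 to compound 4 (beyond the scatter) but still leaves a number 49 percentage points lower from compound 2 to compound 4 (beyond the scatter) in the same read-out. Nothing available explains these differences.

As far as these compounds go, whether the sulfur-to-oxygen exchange or the added methyl drives the rise remains open. Plain furan-2-yl or 5-methylthiophen-2-yl at this position would separate the two.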